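Swapping the aryl group for acetoxymethyl on the triazole

This account rests on a few compounds, and the source may have more. Where it says the series, first, only, none or still open, it means among the compounds named here.

Among the compounds with values here, compound 3 `CCS[C@@H]1[C@H](SCC)[C@@H](Cn2cc(-c3ccccc3C(F)(F)F)nn2)O[C@H]1n1ccc(=O)[nH]c1=O` gives the highest of the three numbers so far in a functional assay on HepG2 cells (Homo sapiens) for cytotoxicity, read by MTT assay, with a stated time of 72 h (on this read-out higher numbers stand for an effect only at larger amounts of compound and lower numbers for an effect already at smaller amounts), namely 30300 nM. Compound 1 `CCS[C@@H]1[C@H](SCC)[C@@H](Cn2cc(-c3ccccc3)nn2)O[C@H]1n1ccc(=O)[nH]c1=O` gives 8380 nM, and compound 2 `CCS[C@@H]1[C@H](SCC)[C@@H](Cn2cc(-c3ccc(F)cc3)nn2)O[C@H]1n1ccc(=O)[nH]c1=O` gives 22600 nM. The measured steps both alter the phenyl ring: a 2.7-fold higher number from compound 1 to compound 2 (0.43 log units; beyond the scatter) for fluoro in place of hydrogen on an aromatic carbon, and a 3.6-fold higher number from compound 1 to compound 3 (0.56 log units; beyond the scatter) for trifluoromethyl in place of hydrogen on an aromatic carbon, while a 1.3-fold higher number from compound 2 to compound 3 (0.13 log units; within the scatter).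

Compound 4 `CCS[C@@H]1[C@H](SCC)[C@@H](Cn2cc(COC(C)=O)nn2)O[C@H]1n1ccc(=O)[nH]c1=O` differs from compound 3 in that (acetoxymethyl in place of 2-(trifluoromethyl)phenyl on an aromatic carbon), on an aromatic carbon of a five-membered aromatic ring with 3 nitrogen. Within the data shown here, no measured step removes the phenyl ring altogether, so none bears directly on this change; the measured steps only show that varying the phenyl moves the number modestly. Compound 4 is therefore expected to stay near compound 3, with the step of a 1.0-fold lower number from compound 3 to compound 4 (0.00 log units; within the scatter) expected to lie within the scatter but carrying wide uncertainty. Compound 4 is estimated at 30000 nM, in a range from 9000 nM to 100000 nM.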

Compound 4, half-maximal effective concentration: >= 100000 nM
Compound 4: a limit, no number (the forecaster's own chance of this, stated with the estimate: 30%); middle value at least 3.3-fold (0.52 log units) from the limit.
By their numbers in this assay, from the lowest: compound 1; then compounds 2 and 3 (each within the scatter of the next). At a limit, above all of these: compound 4.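

In this assay compound 4 stands at a limit of the assay, not at a number: the limit of >= 100000 nM in this assay, at which 1 of the 4 values shown sits.

The earlier compounds shown here varied only the substituents on the phenyl ring, whereas here the whole aryl group leaves this aromatic carbon and acetoxymethyl enters, and the number goes up in all three comparisons: an at least 3.3-fold higher number from compound 3 to compound 4 (0.51 log units; beyond the scatter), an at least 4.4-fold higher number from compound 2 to compound 4 (0.64 log units; beyond the scatter) and an at least 11-fold higher number from compound 1 to compound 4 (1.07 log units; beyond the scatter). This position therefore tolerates more than small shifts, and the step from phenyl itself is large, far beyond what the substituents on that ring produced.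

The compounds shown do not separate the loss of the aromatic ring from the entry of acetoxymethyl, and the full size of these steps stays open at the limit. A hydroxymethyl group, an amine or a plain alkyl chain on this carbon would be needed to tell these apart.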